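The source may report more compounds than this note shows. Statements on the series, on what has been measured and on what is new or still open speak of the compounds shown alone.

compound 1 `CCCCCCCCCCCC(=O)OC[C@H](CSC[C@@H](N)C(=O)NC(C)c1ccccc1)OC(=O)CCCCCCCCCCC`: 9900 nM
compound 2 `CCCCCCCCCCCC(=O)OC[C@H](CSC[C@@H](N)C(=O)NC(C)CCc1ccccc1)OC(=O)CCCCCCCCCCC`: 160 nM
compound 3 `CCCCCCCCCCCC(=O)OC[C@H](CSC[C@@H](N)C(=O)NC(C)c1ccc(O)cc1)OC(=O)CCCCCCCCCCC`: 2890 nM

In an assay on HEK293 cells for agonist activity at Toll-like receptor 2 (Homo sapiens) (on this read-out higher numbers stand for an effect only at larger amounts of compound and lower numbers for an effect already at smaller amounts), compound 3 holds the second highest of the three numbers: a 3.4-fold lower number from compound 1 to compound 3 (0.53 log units; beyond the scatter), whereas an 18-fold higher number from compound 2 to compound 3 (1.26 log units; beyond the scatter). Compound 4 `CCCCCCCCCCCC(=O)OC[C@H](CSC[C@@H](N)C(=O)NCCCCCCCCCC(=O)O)OC(=O)CCCCCCCCCCC` arises from compound 3 by the change (9-carboxynonyl in place of 1-(4-hydroxyphenyl)ethyl on an amide-type nitrogen). Within the data shown here, no measured step covers this exchange directly. Among the measured compounds shown here, the closest precedent is a 62-fold lower number from compound 1 to compound 2 (1.79 log units; beyond the scatter), where a longer group on the same nitrogen went with a much lower number, and a 3.4-fold lower number from compound 1 to compound 3 (0.53 log units; beyond the scatter), where an added hydroxy group gave only a modest shift. The entering 9-carboxynonyl chain is longer again than phenethyl, but its end differs from anything measured, so the direction stays uncertain; a moderate step downward is expected, a 2.9-fold lower number from compound 3 to compound 4 (0.46 log units; beyond the scatter). Compound 4 is therefore estimated at 1000 nM, with a range from 150 nM to 8000 nM.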

Compound 4, half-maximal effective concentration: 4400 nM
Compound 4: the middle estimate sits 4.4-fold (0.64 log units) below what was measured, and the stated range covers the measured number.
By their numbers in this assay, from the lowest: compound 2; then compounds 3 and 4 (each within the scatter of the next); then compound 1.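

In this assay, replacing 1-(4-hydroxyphenyl)ethyl on the amide-type nitrogen with the ring-free 9-carboxynonyl leaves the number within the scatter (a 1.5-fold higher number from compound 3 to compound 4 (0.18 log units; within the scatter)), so a number of this size does not depend on an aromatic ring at this position. This longer chain does not reach the low number given by 1-methyl-3-phenylpropyl (a 28-fold higher number from compound 2 to compound 4 (1.44 log units; beyond the scatter)), and its step from 1-phenylethyl is only modest (a 2.3-fold lower number from compound 1 to compound 4 (0.35 log units; beyond the scatter)). No evidence at hand accounts for these results. The compounds shown leave open whether the chain itself or its carboxylic acid end sets this number. A plain decyl chain or a chain ending in an amine would separate the two.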